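The source may hold more compounds than are shown below. What is called first, only, known or untested is meant among the compounds shown, and "the series" means these compounds.

Of the compounds shown here, three have been measured so far, and all three share the same core, differing only in the group attached to the sulfonyl sulfur. Compound 1 `Cc1ccc(NS(=O)(=O)c2ccc(Cl)cc2)cc1Nc1nccc(-c2cccnc2)n1` gives 11800 nM in a functional assay on MCF7 cells (Homo sapiens) for cytotoxicity, read by MTT assay, with a stated time of 24 h; on this read-out lower numbers stand for stronger inhibition and higher numbers for weaker inhibition. Compound 2 `Cc1ccc(NS(=O)(=O)c2cnc3ccccc3c2)cc1Nc1nccc(-c2cccnc2)n1` gives 9960 nM in this assay. Within the data shown here, the single change between these two, a 1.2-fold lower number from compound 1 to compound 2 (0.07 log units; within the scatter), stays within the scatter of repeated measurements. Compound 3 `COc1cc(-c2ccnc(Nc3cc(NS(=O)(=O)c4ccc(-c5ccccc5)cc4)ccc3C)n2)cc(OC)c1OC` gives 9330 nM in this assay; this is the lowest of the three numbers, but compound 1 and compound 2 both sit within the scatter of it, so no ordering among the three can be claimed.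

Compound 4 `COc1cc(-c2ccnc(Nc3cc(NS(=O)(=O)c4ccc5ccccc5c4)ccc3C)n2)cc(OC)c1OC` has not yet been measured. Its structure differs from compound 3 by one change: naphthalen-2-yl in place of 4-phenylphenyl on a sulfonyl sulfur. Among the measured compounds shown here, the only measured step that bears on this change is the exchange of one aromatic group for another on the sulfonyl sulfur, a 1.2-fold lower number from compound 1 to compound 2 (0.07 log units; within the scatter), which stayed within the scatter. On that basis the step from compound 3 to compound 4 in this assay is expected to be no larger than the scatter, with no particular direction, that is a 1.0-fold lower number from compound 3 to compound 4 (0.00 log units; within the scatter). The estimate for compound 4 in this assay is therefore 9300 nM, with a range from 4000 nM to 22000 nM.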

Compound 4, half-maximal inhibitory concentration: 11600 nM
For compound 4 the middle estimate is 1.2-fold (0.10 log units) below the measured one, and the stated range covers the measured number.
By their numbers in this assay, from the lowest: compounds 3, 2, 4 and 1 (each within the scatter of the next).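

In this assay, the exchange of 4-phenylphenyl for naphthalen-2-yl on a sulfonyl sulfur gives a 1.2-fold higher number from compound 3 to compound 4 (0.09 log units; within the scatter), so the two groups cannot be told apart here, although naphthalen-2-yl has fewer heavy atoms than 4-phenylphenyl. This is the first exchange at this position on the core of compound 3, and it stays within the scatter just as the exchange on the core of compound 1 did, a 1.2-fold lower number from compound 1 to compound 2 (0.07 log units; within the scatter), so both single exchanges shown at this position leave the read-out unresolved. Nothing at hand gives a measured reason for this lack of separation.

Every group shown on the sulfonyl sulfur is aromatic, which leaves open how a non-aromatic group there, such as methyl or cyclohexyl, or an aromatic ring carrying a carboxylic acid or an amine, would read in this assay. Going by these compounds, no single group appears on both cores either, so it also remains open whether one and the same group on the sulfonyl sulfur would read alike on the core of compound 1 and the core of compound 3.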